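The compounds below may be only part of what the source reports. "The series", "measured", "known", "first", "only" and "open" are said of these compounds alone.

Compounds measured so far in an ADME assay on HepG2 2.2.15 cells (Homo sapiens) for cytotoxicity; a lower number here means that less compound is tolerated, a higher number that more compound is tolerated:
compound 1, `CCCCC(=O)OCCc1c(-c2ccccc2Cl)c2cc(Cl)ccc2[nH]c1=O`, 200000 nM
compound 2, `O=C(OCCc1c(-c2ccccc2Cl)c2cc(Cl)ccc2[nH]c1=O)C1CCCC1`, 46000 nM
compound 3, `C/C=C/C=C/C(=O)OCCc1c(-c2ccccc2Cl)c2cc(Cl)ccc2[nH]c1=O`, 440000 nM

Compound 2 stands lowest of the three; the steps of a 4.3-fold lower number from compound 1 to compound 2 (0.64 log units; beyond the scatter) and a 9.6-fold higher number from compound 2 to compound 3 (0.98 log units; beyond the scatter) are both beyond the scatter. Compound 4, `C/C=C(\C)C(=O)OCCc1c(-c2ccccc2Cl)c2cc(Cl)ccc2[nH]c1=O`, differs from compound 2 by 1-methylprop-1-en-1-yl in place of cyclopentyl on a carbonyl carbon. For the measured compounds named here, two measured steps bear on this: a 9.6-fold higher number from compound 2 to compound 3 (0.98 log units; beyond the scatter), where an open unsaturated chain likewise replaces the cyclopentyl, and a 4.3-fold lower number from compound 1 to compound 2 (0.64 log units; beyond the scatter), read in reverse, where an open saturated chain stands in its place. Both point the same way, so a modest rise in this assay is expected for compound 4. The estimate for compound 4 is 250000 nM, with a range from 80000 nM to 600000 nM, meaning an expected step of a 5.4-fold higher number from compound 2 to compound 4 (0.74 log units; beyond the scatter).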

Compound 4, half-maximal cytotoxic concentration: 350000 nM
Compound 4: middle estimate off by 1.4-fold (0.15 log units), on the low side; measured number inside the range.
By their numbers in this assay, from the lowest: compound 2; then compounds 1, 4 and 3 (each within the scatter of the next, the first and the last beyond it).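

With the new group the first marked step is large: in this assay, 1-methylprop-1-en-1-yl in place of cyclopentyl gives (a 7.6-fold higher number from compound 2 to compound 4 (0.88 log units; beyond the scatter)), so a second unsaturated group without a ring stands well clear of compound 2. For the compounds shown here, the same group cannot be separated from penta-1,3-dien-1-yl (a 1.3-fold lower number from compound 3 to compound 4 (0.10 log units; within the scatter)) or from butyl (a 1.8-fold higher number from compound 1 to compound 4 (0.24 log units; within the scatter)), and so compound 2 alone, the only one with a ring at this carbonyl carbon, stands apart from compound 4. Nothing measured here gives a reason for these differences.

As far as these compounds go, it remains open whether the low number belongs to cyclopentyl in particular or to rings at this place generally. A cyclohexyl or cyclopropyl group, or a chain carrying an amine, would bear on that.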